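Swapping the azole ring on a fused core

This account rests on a few compounds, and the source may have more. Where it says the series, first, only, none or still open, it means among the compounds named here.

Compound 2 `CCc1c(OC)nc2nc(-c3nnco3)cn2c1C` — > 50 mg/kg
Compound 1 `CCc1c(SC)nc2nc(-c3noc(C)n3)cn2c1C` — 2 mg/kg
Compound 3 `CCCc1c(OC)nc2nc(-c3nnc(C)o3)cn2c1C` — 10 mg/kg

Of the compounds shown here, three on a shared core have been tested in a functional assay on the whole organism with Rattus norvegicus as the target; on this read-out lower numbers stand for an effect already at smaller amounts and higher numbers for an effect only at larger amounts of compound. Compound 1 gives 2 mg/kg and compound 3 gives 10 mg/kg. For compound 2 the result is only a limit of the assay, > 50 mg/kg; compound 2 therefore sits at the limit of > 50 mg/kg in this assay, at which 1 of the 3 values shown sits, the weakest end of what has been seen so far.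

Compound 4 `CCc1c(OC)nc2nc(-c3cc(C)[nH]n3)cn2c1C` differs from compound 2 in one place: 5-methyl-1H-pyrazol-3-yl in place of 1,3,4-oxadiazol-2-yl on an aromatic carbon. Among the compounds with values here, no measured pair shows this same change, so its size can only be guessed. The two compounds that reach a measurable dose, compound 1 and compound 3, each carry a methyl-bearing azole, while compound 2 carries the bare 1,3,4-oxadiazol-2-yl. The account therefore expects compound 4 to improve on compound 2 by a modest step, an at least 1.6-fold lower number from compound 2 to compound 4 (0.22 log units; that floor lies within the scatter), in the direction of smaller doses, though a result that again stays at the limit cannot be ruled out. Compound 4 is estimated at 30 mg/kg, with a plausible range from 8 mg/kg to 100 mg/kg.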

Compound 4, minimum effective dose: > 50 mg/kg
Compound 4 was reported as a limit (the forecaster's own chance of this, stated with the estimate: 40%); middle value at least 1.6-fold (0.22 log units) from the limit.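

In this assay, within the data shown here, compound 4 gives > 50 mg/kg, a limit of the assay, just as compound 2 stops at a limit, so no step between compound 2 and compound 4 can be read. The compounds shown leave open whether either azole, 5-methyl-1H-pyrazol-3-yl or 1,3,4-oxadiazol-2-yl, has the lower minimum effective dose on this core.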